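A few compounds are considered here, and "the series" means these few. Any claim that something is new, unique, unknown or untested is made for them only; others in the source may bear on it.

Measured in a physicochemical assay for solubility, in phosphate buffer, at pH 7.4; on this read-out higher numbers stand for higher solubility and lower numbers for lower solubility:
compound 1 `CC(=O)N[C@@H]1CCC[C@H](C(=O)Nc2cc(-c3cnn4c3CCCC4)c(Cl)cn2)C1` 310000 nM
compound 2 `CC(=O)N[C@@H]1CCC[C@H](C(=O)Nc2cc(-c3cnc4ccccn34)c(Cl)cn2)C1` 120000 nM
compound 3 `CC(=O)N[C@@H]1CCC[C@H](C(=O)Nc2cc(-c3cnn4c3CCCCC4)c(Cl)cn2)C1` 104000 nM

Compound 3 sits at the low end of these numbers, level within the scatter with its nearest neighbour (a 1.2-fold lower number from compound 2 to compound 3 (0.06 log units; within the scatter)) and clearly apart from the furthest (a 3.0-fold lower number from compound 1 to compound 3 (0.47 log units; beyond the scatter)). The change to compound 4 `CC(=O)N[C@@H]1CCC[C@H](C(=O)Nc2cc(-c3cnn4c3CN(C)CC4)c(Cl)cn2)C1` is a group of 10 heavy atoms (7 carbon, 3 nitrogen; one five-membered aromatic ring with 2 hetero atoms, one six-membered non-aromatic ring with 2 hetero atoms) in place of a group of 10 heavy atoms (8 carbon, 2 nitrogen; one five-membered aromatic ring with 2 hetero atoms, one seven-membered non-aromatic ring with 1 hetero atom), on an aromatic carbon.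

The closest guide is the modest measured step between a six-membered and a seven-membered non-aromatic ring (a 3.0-fold lower number from compound 1 to compound 3 (0.47 log units; beyond the scatter)), read here in reverse. The step to the six-membered aromatic ring (a 2.6-fold lower number from compound 1 to compound 2 (0.41 log units; beyond the scatter)) bears on it less directly. For the measured compounds named here, no measured step covers a six-membered non-aromatic ring with 2 hetero atoms, so the range stays wide. In this assay a modest rise is therefore expected, and the estimate means a 2.9-fold higher number from compound 3 to compound 4 (0.46 log units; beyond the scatter) beyond what compound 3 shows. For compound 4 the estimated value is 300000 nM, with an expected range from 100000 nM to 800000 nM.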

Compound 4, solubility: 870000 nM
Beside the measured number, compound 4's estimate is 2.9-fold (0.46 log units) below it, and the stated range ends below it.
By their numbers in this assay, from the lowest: compounds 3 and 2 (each within the scatter of the next); then compound 1; then compound 4.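

In this assay, for the compounds shown here, this aromatic carbon, opposite the ring nitrogen, carries a wider spread of numbers than the earlier compounds showed: the six-membered non-aromatic ring with 2 hetero atoms gives an 8.4-fold higher number from compound 3 to compound 4 (0.92 log units; beyond the scatter) and a 7.3-fold higher number from compound 2 to compound 4 (0.86 log units; beyond the scatter). Ring size alone does not set the number, since compounds 1 and 4 both carry a six-membered non-aromatic ring and still differ, with a 2.8-fold higher number from compound 1 to compound 4 (0.45 log units; beyond the scatter). No available measurement accounts for these steps.

Open, as far as these compounds go, is whether the number follows the second ring nitrogen itself or the methyl group it carries; a ring oxygen in its place, a ring amine with hydrogen on that nitrogen, or a longer chain there would separate these readings. Also open, from the compounds shown here alone, is whether a carboxylic acid on the same ring would fall in this range.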